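Four Related Compounds and One Expected Limit

A few compounds are considered here, and "the series" means these few. Any claim that something is new, unique, unknown or untested is made for them only; others in the source may bear on it.

Three compounds share a common core and differ in two places. Compound 1, `CCCCCCCCCCCSC(=S)C1=C(Nc2ccc(Cl)cc2Cl)CC(C)(C)CC1=O`, carries a decyl chain on a sulfur and a (2,4-dichlorophenyl)amino group. Compound 2, `CC1(C)CC(=O)C(C(=S)SCc2ccccc2)=C(Nc2ccc(Cl)cc2Cl)C1`, keeps that amino group but differs from compound 1 in one respect: phenyl in place of decyl on a saturated chain carbon bound to a sulfur. Compound 3, `CCCCCCCCCCCSC(=S)C1=C(Nc2ccc(Cl)cc2)CC(C)(C)CC1=O`, keeps the decyl chain and differs from compound 1 in the core: hydrogen in place of chloro on an aromatic carbon.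

All three were tested in a functional assay on cells (blood, Homo sapiens) for inhibition, read by chemiluminescence, with a stated time of 30 min; on this read-out higher numbers stand for weaker inhibition and lower numbers for stronger inhibition. In this assay compound 1 gives a value that is only a limit of the assay, > 100 ug/mL. Compound 2 likewise gives only a limit, > 100 ug/mL. Compound 3 also gives only a limit, > 100 ug/mL. This leaves a step that the two limits leave unreadable from compound 1 to compound 2 and a step that the two limits leave unreadable from compound 1 to compound 3, since values sitting at the limit of > 100 ug/mL in this assay, at which 3 of the 3 values shown sit, allow no reading of size or direction.

Compound 4, `CC1(C)CC(=O)C(C(=S)SCc2ccccc2)=C(Nc2ccc(Cl)cc2)C1`, has not yet been measured. It differs from compound 3 by the same change that separates compound 1 from compound 2, (phenyl in place of decyl on a saturated chain carbon bound to a sulfur), in the same place. Among the measured compounds shown here, the expected step is a step that the limit leaves unreadable from compound 3 to compound 4, and this expectation rests only on the observation that every compound so far sits at the limit of > 100 ug/mL in this assay, at which 3 of the 3 values shown sit, so the change has never produced a readable number. Compound 4 is therefore expected to give 200 ug/mL, most likely again only a limit of the assay, with a plausible range from 100 ug/mL to 500 ug/mL.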

Compound 4, half-maximal inhibitory concentration: > 100 ug/mL
Compound 4: a limit, no number; the forecaster's own chance of this, stated with the estimate: 85%; the middle value does not contradict the limit.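

In this assay compound 4 gives > 100 ug/mL, which is a limit of the assay and not a number. Among the compounds shown here, neither the step from compound 3 to compound 4 nor the one from compound 2 to compound 4 can be read, because every compound sits at the same limit: the limit of > 100 ug/mL in this assay, at which 4 of the 4 values shown sit. The compounds shown leave open how strongly any of them inhibits, and whether either change alters that at all.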